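The source may hold more compounds than are shown below. What is called first, only, known or untested is meant among the compounds shown, and "the series" means these compounds.

Compound 3 `Cc1ccc(C(=O)N2CCN(Cc3nc4ccccc4n3Cc3cccc(C)c3)CC2)cc1` gives 64.9% in an assay on isolated protein for inhibition of aldehyde dehydrogenase 1A1 (Homo sapiens), read by spectrophotometry, tested at 10 uM; on this read-out lower numbers stand for less inhibition and higher numbers for more inhibition at the one concentration tested (going by the name of the read-out); compound 2 `Cc1cccc(Cn2c(CN3CCN(C(=O)c4ccc(C(C)C)cc4)CC3)nc3ccccc32)c1` gives 67.6%, and the gap of a number 2.7 percentage points lower from compound 2 to compound 3 (within the scatter) is within the scatter, so the two cannot be ordered. Compound 1 `CCC(=O)N1CCN(Cc2nc3ccccc3n2Cc2cccc(C)c2)CC1` gives 85.1% and stands clearly apart from both. The unmeasured compound 4 `Cc1cccc(Cn2c(CN3CCN(C(=O)C(C)C)CC3)nc3ccccc32)c1` differs from compound 3 in one place: isopropyl in place of 4-methylphenyl on a carbonyl carbon. For the measured compounds named here, the steps that bear on this are the two in which an aryl group entered in place of ethyl on the carbonyl carbon, a number 17.5 percentage points lower from compound 1 to compound 2 (beyond the scatter) and a number 20.2 percentage points lower from compound 1 to compound 3 (beyond the scatter), both modest losses. Putting isopropyl in place of 4-methylphenyl runs the other way, so a modest gain back toward compound 1 is expected, a number 17.1 percentage points higher from compound 3 to compound 4 (beyond the scatter). Compound 4 is estimated at 82%, with a range from 68% to 93%.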

Compound 4, a percentage reported as inhibition, at one concentration (the size of the read-out at that concentration, not a potency): 87.2%
Compound 4: middle estimate off by 5.2 percentage points, on the low side; low and high end bracket the measured number.
By their numbers in this assay, from the lowest: compounds 3 and 2 (each within the scatter of the next); then compounds 1 and 4 (each within the scatter of the next).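

On the carbonyl carbon the loss seen with the aryl groups is now recovered from both sides in this assay: isopropyl in place of 4-methylphenyl gives a number 22.3 percentage points higher from compound 3 to compound 4 (beyond the scatter) and isopropyl in place of 4-isopropylphenyl gives a number 19.6 percentage points higher from compound 2 to compound 4 (beyond the scatter). The extra methyl on the saturated chain gives a number 2.1 percentage points higher from compound 1 to compound 4 (within the scatter) and so leaves ethyl and isopropyl unordered at this position. Nothing available accounts for the gap between the aryl and saturated groups. Open, on these data alone, is how far the saturated chain can grow before the number falls, as with a longer chain such as hexyl or a ring such as cyclohexyl. Also open, as far as these compounds go, is whether unsubstituted phenyl on the carbonyl carbon sits with the aryl compounds.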